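Swapping the amide's 4-methylphenyl for 2-hydroxyethyl

The source may hold more compounds than are shown below. What is called first, only, known or untested is meant among the compounds shown, and "the series" means these compounds.

Measured in an ADME assay on Huh-7 cells (Homo sapiens) for cytotoxicity, read by a luciferase reporter and WST assay, with a stated time of 3 days; on this read-out lower numbers stand for higher toxicity in this test and higher numbers for lower toxicity in this test:
- compound 1 `Cc1ccc(NC(=O)c2c(NO)cc(-c3ccccc3)oc2=O)cc1`: > 20000 nM
- compound 2 `Cc1ccc(NC(=O)c2c(NO)cc(-c3ccc(C)cc3)oc2=O)cc1`: > 20000 nM

Each entry is a limit of the test and not a number.

Compound 2 reads > 20000 nM, and this is the limit of > 20000 nM in this assay, at which 2 of the 2 values shown sit. Among the measured compounds shown here, the only measured step, a step that the two limits leave unreadable from compound 1 to compound 2, was a methyl in place of hydrogen on an aromatic carbon, so it says nothing about the amide. Compound 3 `Cc1ccc(-c2cc(NO)c(C(=O)NCCO)c(=O)o2)cc1` carries a different change: 2-hydroxyethyl in place of 4-methylphenyl on an amide-type nitrogen. Here 2-hydroxyethyl stands in place of 4-methylphenyl on an amide-type nitrogen. For the measured compounds named here, no measured step touches that place, so the expectation rests only on compound 2 reading > 20000 nM. Compound 3 is expected to show no clear toxicity in this assay either. The estimated size is a step that the limit leaves unreadable from compound 2 to compound 3, expected to stay within the usual scatter, with no firm direction. Compound 3 is estimated at 25000 nM, with an expected range from 15000 nM to 50000 nM.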

Compound 3, half-maximal cytotoxic concentration: > 20000 nM
Compound 3 was reported as a limit; the forecaster's own chance of this, stated with the estimate: 85%; the middle value does not contradict the limit.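

Among the compounds shown here, compound 2 and compound 3 are both reported only as limits and not as numbers, so no step between them can be read in this assay. All the results shown stop at the same point: the limit of > 20000 nM in this assay, at which 3 of the 3 values shown sit.

The compounds shown leave open at what concentration any of them would become toxic in this assay, and whether 2-hydroxyethyl in place of 4-methylphenyl changes that concentration at all.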